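Trifluoromethyl in Place of Methoxy: Compound 1 to Compound 4

The source may hold more compounds than are shown below. What is called first, only, known or untested is meant among the compounds shown, and "the series" means these compounds.

Measured compounds:
compound 1, `COc1ccc(-c2cn(C[C@H]3c4c(ccc(O)c4C)[C@@H]4CC[C@@]5(C)C[C@]43CC5=O)nn2)cc1`, > 20000 nM
compound 2, `C=C1C[C@]23C[C@@]1(O)CC[C@H]2c1ccc(OS(=O)(=O)c2ccc(C)cc2)c(C)c1[C@@H]3Cn1cc(-c2ccc(C)cc2)nn1`, > 20000 nM
compound 3, `C=C1C[C@]23C[C@@]1(O)CC[C@H]2c1ccc(O)c(C)c1[C@@H]3Cn1cc(-c2ccc(F)cc2)nn1`, > 20000 nM

Of the compounds shown here, three have been tested in a functional assay on HL-60 cells (Homo sapiens) for cytotoxicity, read by MTT assay, with a stated time of 4 days; on this read-out lower numbers stand for stronger inhibition and higher numbers for weaker inhibition. Compound 1 gives only a limit of the assay, > 20000 nM, and no number. Compound 2 likewise returns only a limit, > 20000 nM. Compound 3 also returns only a limit, > 20000 nM. Compound 1 therefore stands nowhere on a scale of numbers: it sits at the limit, as the evidence shows, (the limit of > 20000 nM in this assay, at which 3 of the 3 values shown sit). For the measured compounds named here, no step between measured compounds that differ in one place is available.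

The untested compound is compound 4, `Cc1c(O)ccc2c1[C@H](Cn1cc(-c3ccc(C(F)(F)F)cc3)nn1)[C@@]13CC(=O)[C@@](C)(CC[C@@H]21)C3`. It differs from compound 1 in one place: trifluoromethyl in place of methoxy on an aromatic carbon.

Going by the values given here, with every measured value at the limit in this assay, there is no measured step on which to found a direction, so the step from compound 1 to compound 4 is expected to be none beyond the scatter, a number no higher from compound 1 to compound 4 (the limit leaves the size open). Compound 4 is accordingly estimated at 20000 nM, within a range from 6000 nM to 40000 nM, with a limit rather than a number being the most likely outcome.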

Compound 4, half-maximal inhibitory concentration: > 20000 nM
Compound 4 gave a limit, no number; the forecaster's own chance of this, stated with the estimate: 80%; the middle value sits exactly at the limit.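

In this assay compound 4 gives > 20000 nM as a limit and not a number. For the compounds shown here, compound 1 also stands at a limit, and no step from compound 1 to compound 4 can be read. The compounds shown leave open what any single change in structure does to the read-out: the limit of > 20000 nM in this assay, at which 4 of the 4 values shown sit.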